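Notes on a substituent change at the shared core

This account rests on a few compounds, and the source may have more. Where it says the series, first, only, none or still open, it means among the compounds named here.

Measured so far in an assay on isolated protein for inhibition of activin receptor type-2A (Homo sapiens), read by 33P incorporation, with a stated time of 20 min, in the presence of a further agent that is not named here; a lower number here means a stronger inhibitor, a higher number a weaker inhibitor:
compound 1 `CCc1nc2c(-c3ccnc(OC)c3)cnn2cc1OC`: 960 nM
compound 2 `COc1cc(-c2cnn3cc(OC)c(-c4cc(C)no4)nc23)ccn1`: 3000 nM
compound 3 `COc1cc(-c2cnn3cc(OC)c(C)nc23)ccn1`: 1200 nM

Compound 3 holds the second highest of the three numbers. Its nearest neighbour is compound 1, and the pair lie within the scatter of each other, as the step of a 1.3-fold higher number from compound 1 to compound 3 (0.10 log units; within the scatter) shows. Compound 2 is the furthest away; the step of a 2.5-fold lower number from compound 2 to compound 3 (0.40 log units; beyond the scatter) goes beyond the scatter, and the step of a 3.1-fold higher number from compound 1 to compound 2 (0.49 log units; beyond the scatter) tells the same thing from the other side: an aromatic ring on that carbon gave a higher number than either ethyl or methyl.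

Compound 4 `COc1cc(-c2cnn3cc(OC)c([C@@H]4COC(C)(C)C4)nc23)ccn1` has not been measured. It differs from compound 3 by a group of 7 heavy atoms (6 carbon, 1 oxygen; one five-membered non-aromatic ring with 1 hetero atom) in place of one carbon atom, on an aromatic carbon. Going by the values given here, the steps that bear on this are the small step from ethyl to methyl and the larger step to the aromatic ring; the entering group here is saturated, so neither is a close match. A step of a 1.2-fold lower number from compound 3 to compound 4 (0.08 log units; within the scatter) is expected, that is nothing clearly beyond the scatter in either direction, with wide uncertainty. For compound 4 the estimate in this assay is 1000 nM, with a range from 250 nM to 4000 nM.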

Compound 4, half-maximal inhibitory concentration: 5300 nM
The estimate for compound 4 lay 5.3-fold (0.72 log units) below the measured number; measured number outside the range, above it.
By their numbers in this assay, from the lowest: compounds 1 and 3 (each within the scatter of the next); then compounds 2 and 4 (each within the scatter of the next).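

In this assay, going by these compounds alone, a saturated ring on this aromatic carbon does not stay with the small alkyl groups, as both a 4.4-fold higher number from compound 3 to compound 4 (0.65 log units; beyond the scatter) and a 5.5-fold higher number from compound 1 to compound 4 (0.74 log units; beyond the scatter) go beyond the scatter; the earlier compounds showed such a rise only with an aromatic ring. The step of a 1.8-fold higher number from compound 2 to compound 4 (0.25 log units; within the scatter) stays within the scatter, so in this set the 3-methyl-1,2-oxazol-5-yl group and the saturated five-membered ring cannot be told apart, and the groups of 6 and 7 heavy atoms both stand apart from ethyl and methyl. No measurement at hand explains the rise.

Open, going by these compounds, is whether the opposite configuration at the defined stereocentre gives a different number. Also open, on these data alone, is whether a cyclopropyl ring or an amine on this carbon would stay with ethyl and methyl or join compound 2 and compound 4.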